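Swapping the amide end for a larger aromatic group

This account rests on a few compounds, and the source may have more. Where it says the series, first, only, none or still open, it means among the compounds named here.

Measured in a functional assay on Caco-2 cells (Homo sapiens), read by MTT assay, with a stated time of 48 h; on this read-out higher numbers stand for weaker inhibition and lower numbers for stronger inhibition:
- Compound 1 `CCOC(=O)CN(C)C(=O)c1ccc(C(CC)(CC)c2ccc(OCC(O)C(C)(C)C)c(C)c2)n1CC`: 12200 nM
- Compound 2 `CCn1c(C(=O)N(C)CCC#N)ccc1C(CC)(CC)c1ccc(OCC(O)C(C)(C)C)c(C)c1`: > 50000 nM (a limit of the assay, not a number)
- Compound 3 `CCn1c(C(=O)N(C)CC(=O)O)ccc1C(CC)(CC)c1ccc(OCC(O)C(C)(C)C)c(C)c1`: 31900 nM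

Of the two exact numbers, compound 3 has the higher, the gap being a 2.6-fold higher number from compound 1 to compound 3 (0.42 log units; beyond the scatter). Compound 4 `CCn1c(C(=O)Oc2ccc(CCO)cc2)ccc1C(CC)(CC)c1ccc(OCC(O)C(C)(C)C)c(C)c1` keeps the shared core but changes what sits on the carbonyl carbon: a group of 10 heavy atoms (8 carbon, 2 oxygen; one six-membered aromatic ring of carbon only) in place of a group of 6 heavy atoms (3 carbon, 1 nitrogen, 2 oxygen; no ring), on a carbonyl carbon. That gap and an at least 4.0-fold higher number from compound 1 to compound 2 (0.61 log units; beyond the scatter) both come from edits within the leaving group. Neither replaces it whole, so they guide only loosely. With compound 3 at 31900 nM, already high in this assay, a modest move to a lower number is expected rather than a further rise. The expected step is a 2.3-fold lower number from compound 3 to compound 4 (0.36 log units; beyond the scatter). For compound 4 the estimated value is 14000 nM, with an expected range of 5000 nM to 45000 nM.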

Compound 4, half-maximal inhibitory concentration: > 50000 nM
Compound 4 gave a limit, no number; the forecaster's own chance of this, stated with the estimate: 20%; middle value at least 3.5-fold (0.55 log units) away from the limit.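

Compound 4 is the only one shown that puts a six-membered aromatic ring of carbon only, rather than an open chain, on the carbonyl carbon, and this whole replacement brings no lower number in this assay. The steps are an at least 4.0-fold higher number from compound 1 to compound 4 (0.61 log units; beyond the scatter) and an at least 1.5-fold higher number from compound 3 to compound 4 (0.19 log units; that floor lies within the scatter), though that second floor lies within the scatter. Compound 4 gives a limit of the assay, not a number: the limit of > 50000 nM in this assay, at which 2 of the 4 values shown sit.

The step between compound 2 and compound 4 cannot be read, as both are limits. As far as these compounds go, whether an aromatic ring carrying an amine or a carboxylic acid would give a lower number stays open.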